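Bromo to carbamoyl on the acyl chain: cytotoxicity notes

The compounds below may be only part of what the source reports. "The series", "measured", "known", "first", "only" and "open" are said of these compounds alone.

Measured in an ADME assay on CCRF-CEM cells (Homo sapiens) for cytotoxicity, with a stated time of 4 days; on this read-out lower numbers stand for higher toxicity in this test and higher numbers for lower toxicity in this test:
- compound 1 `Cc1cn([C@@H]2O[C@H](CO[Si](C)(C)C(C)(C)C)[C@@]3(OS(=O)(=O)C=C3N)[C@H]2O[Si](C)(C)C(C)(C)C)c(=O)n(C(=O)OC(C)(C)C)c1=O`: 26000 nM
- compound 2 `Cc1cn([C@@H]2O[C@H](CO[Si](C)(C)C(C)(C)C)[C@@]3(OS(=O)(=O)C=C3N)[C@H]2O[Si](C)(C)C(C)(C)C)c(=O)n(C(=O)c2ccccc2)c1=O`: 54000 nM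
- compound 3 `Cc1cn([C@@H]2O[C@H](CO[Si](C)(C)C(C)(C)C)[C@@]3(OS(=O)(=O)C=C3N)[C@H]2O[Si](C)(C)C(C)(C)C)c(=O)n(C(=O)CCCBr)c1=O`: 11000 nM

Compound 3 gives the lowest number of the three. The measured steps to it are a 2.4-fold lower number from compound 1 to compound 3 (0.37 log units; beyond the scatter) and a 4.9-fold lower number from compound 2 to compound 3 (0.69 log units; beyond the scatter).

The next compound is compound 4 `Cc1cn([C@@H]2O[C@H](CO[Si](C)(C)C(C)(C)C)[C@@]3(OS(=O)(=O)C=C3N)[C@H]2O[Si](C)(C)C(C)(C)C)c(=O)n(C(=O)CCCC(N)=O)c1=O`, with the change (carbamoyl in place of bromo on a saturated chain carbon, three bonds along the chain from a carbonyl carbon). Carbamoyl stands in place of bromo on a saturated chain carbon, three bonds along the chain from a carbonyl carbon.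

Going by the values given here, no measured step makes this exact swap. The nearest evidence is the set of group changes on the same carbonyl carbon, including a 2.1-fold higher number from compound 1 to compound 2 (0.32 log units; beyond the scatter), and all of these are modest. With compound 3 at 11000 nM, the lowest of the series, a modest rise in this assay is expected rather than a further fall. The expected step is a 1.8-fold higher number from compound 3 to compound 4 (0.26 log units; within the scatter). For compound 4 the estimated value is 20000 nM, with an expected range of 8000 nM to 50000 nM.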

Compound 4, half-maximal cytotoxic concentration: 8700 nM
Beside the measured number, compound 4's estimate is 2.3-fold (0.36 log units) above it; the range from low to high includes it.
By their numbers in this assay, from the lowest: compounds 4 and 3 (each within the scatter of the next); then compound 1; then compound 2.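

In this assay, carbamoyl and bromo at this chain position cannot be told apart (a 1.3-fold lower number from compound 3 to compound 4 (0.10 log units; within the scatter)), so among these compounds the low number of the 3-bromopropyl acyl group does not depend on the bromine. The 3-carbamoylpropyl group also stays well apart from the other two acyl groups (a 6.2-fold lower number from compound 2 to compound 4 (0.79 log units; beyond the scatter) and a 3.0-fold lower number from compound 1 to compound 4 (0.48 log units; beyond the scatter)), which extends the separation of the two chain-bearing compounds from those carrying phenyl and tert-butoxy to a second chain end. Nothing available accounts for compound 3 and compound 4 reading alike.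

On these data alone, whether a carboxylic acid or an amine at the same chain end would read with compound 3 and compound 4 stays open. Also open, as far as these compounds go, is whether a longer chain ending in carbamoyl would keep this low number or move toward compound 2.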